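The source may hold more compounds than are shown below. What is called first, only, known or untested is meant among the compounds shown, and "the series" means these compounds.

Working notes on the series. Compound 1 `CCCCCCOc1ccc2c(Cl)ccnc2c1` is the reference point; it is varied at the chain on the oxygen on the aromatic ring and at the chloro on an aromatic carbon. In a functional assay on SK-OV-3 cells (Homo sapiens) for cytotoxicity, read by MTT assay, with a stated time of 48 h (a lower number here means a stronger inhibitor, a higher number a weaker inhibitor), compound 1 gives only a limit, > 10000 nM, which is the limit of > 10000 nM in this assay, at which 1 of the 3 values shown sits. Compound 2 `CCCCCCOc1ccc2c(NCCN(C)C)ccnc2c1` gives 1860 nM in this assay, and compound 3 `CC(C)Oc1ccc2c(Cl)ccnc2c1` gives 3060 nM. The step of an at least 5.3-fold lower number from compound 1 to compound 2 (0.73 log units; beyond the scatter) alters the chloro site, while an at least 3.2-fold lower number from compound 1 to compound 3 (0.51 log units; beyond the scatter) shortens the chain on the oxygen. From the compounds shown here alone, both run to lower numbers from the limit of compound 1, and since compound 1 carries only a limit, its true position beyond that is unknown.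

Compound 4 `CCCCCCCCOc1ccc2c(Cl)ccnc2c1`, not yet measured, differs from compound 1 by ethyl in place of hydrogen on a saturated chain carbon, six bonds along the chain from an oxygen on an aromatic ring. Only the change in chain length bears on this, and it points the other way: in an at least 3.2-fold lower number from compound 1 to compound 3 (0.51 log units; beyond the scatter) the shorter isopropyl gave the lower number, so the longer chain of compound 4 is expected to sit at or past the limit side rather than move toward a lower number. No step beyond the scatter toward a lower number is expected for compound 4. The estimate for compound 4 in this assay is 15000 nM, within 6000 nM to 40000 nM, an expected step that the limit leaves unreadable from compound 1 to compound 4, with a bare limit the likelier report.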

Compound 4, half-maximal inhibitory concentration: 4300 nM
Estimate against measurement, compound 4: 3.5-fold (0.54 log units) above, and the stated range ends above it.
By their numbers in this assay, from the lowest: compounds 2, 3 and 4 (each within the scatter of the next, the first and the last beyond it). At a limit, above all of these: compound 1.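

In this assay, the step of an at least 2.3-fold lower number from compound 1 to compound 4 (0.36 log units; beyond the scatter) shows that lengthening the chain on the oxygen, with ethyl in place of hydrogen on a saturated chain carbon, six bonds along the chain from an oxygen on an aromatic ring, also leads to a lower number. With the isopropyl chain of compound 3 also running lower, a shorter and a longer chain both depart from compound 1, which stays a limit, so chain length on the oxygen follows no single direction across these compounds and the true size of neither step can be read: the limit of > 10000 nM in this assay, at which 1 of the 4 values shown sits.
Compound 3 at 3060 nM and compound 4 at 4300 nM lie within the scatter of each other, so these two chains cannot be told apart here.

The compounds shown leave open how a butyl chain or a chain longer than that of compound 4 would read on the shared core. They also leave open whether the (2-(dimethylamino)ethyl)amino group at the chloro site, or a different amine there, would give a further step when paired with the isopropyl chain or the longer chain of compound 4.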